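Chloro in place of methoxy on the pendant aryl

This account rests on a few compounds, and the source may have more. Where it says the series, first, only, none or still open, it means among the compounds named here.

Measured so far:
compound 1 `COc1cccc([C@@H](CO)O[C@H]2CCCN(Cc3ccc(C(=O)O)cc3C)[C@H]2c2ccccc2)c1` gives 81000 nM
compound 2 `Cc1nc(C(=O)O)ccc1CN1CCC[C@H](O[C@H](CO)c2cc(Cl)cc(Cl)c2)[C@@H]1c1ccccc1` gives 370 nM
compound 3 `COC(=O)Nc1cc(C(=O)O)ccc1CN1CCC[C@H](O[C@H](CO)c2cc(Cl)cc(Cl)c2)[C@@H]1c1ccccc1` gives 1000 nM

In an assay on isolated protein for activation of cGMP-dependent protein kinase 1 (Homo sapiens), read by ADP-Glo, with stated times of 30 min and 2 h, in the presence of a further agent that is not named here (a higher number here means that more compound is needed for the effect, a lower number that less compound is needed), compound 1 stands highest of the three numbers; compound 3 lies far below it, beyond the scatter, and compound 2 further still. Compound 4 `Cc1cc(C(=O)O)ccc1CN1CCC[C@H](O[C@H](CO)c2cccc(Cl)c2)[C@@H]1c1ccccc1` is not yet measured. It differs from compound 1 by chloro in place of methoxy on an aromatic carbon. Within the data shown here, no measured pair isolates this single change, and compounds 2 and 3 differ from compound 1 in more than one place. Since compound 2 with 370 nM and compound 3 with 1000 nM both carry chloro on that ring and sit far lower, a sizeable downward step is expected, a 14-fold lower number from compound 1 to compound 4 (1.13 log units; beyond the scatter). For compound 4 the estimate is 6000 nM, range 1500 nM to 25000 nM.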

Compound 4, half-maximal effective concentration: 1300 nM
The estimate for compound 4 lay 4.6-fold (0.66 log units) above the measured number; measured number outside the range, below it.
By their numbers in this assay, from the lowest: compound 2; then compounds 3 and 4 (each within the scatter of the next); then compound 1.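

In this assay, chloro in place of methoxy on this aromatic carbon gives a 62-fold lower number from compound 1 to compound 4 (1.79 log units; beyond the scatter). Among these compounds, this is the first reading of the change on its own, and it shows that this single swap, 3-methoxyphenyl to 3-chlorophenyl, is enough for a large step with the rest of compound 1 kept. No measurement shown accounts for the size of this step.

Open, as far as these compounds go, is whether the step is particular to chloro. A bromo, nitrile or trifluoromethyl group on the same aromatic carbon would test this.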